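Swapping the Aryl Group on a Triazole-Linked Lactone

This account rests on a few compounds, and the source may have more. Where it says the series, first, only, none or still open, it means among the compounds named here.

Measured compounds:
Compound 1 `O=C1O/C(=C\Cn2cc(-c3cc(F)cc(F)c3)nn2)C(OCc2ccccc2)=C1OCc1ccccc1` gives 17700 nM
Compound 2 `O=C1O[C@H]([C@@H](O)Cn2cc(-c3cc(F)cc(F)c3)nn2)C(OCc2ccccc2)=C1OCc1ccccc1` gives 40800 nM
Compound 3 `COc1ccccc1-c1cn(C/C=C2\OC(=O)C(OCc3ccccc3)=C2OCc2ccccc2)nn1` gives > 100000 nM

These three share one core and differ in the group on the triazole ring or in the linker to it. In a functional assay on HeLa cells (Homo sapiens) for antiproliferative activity, read by MTT assay, with a stated time of 72 h (on this read-out lower numbers stand for stronger inhibition and higher numbers for weaker inhibition), compound 1 gives 17700 nM. Compound 2 gives 40800 nM in this assay, the highest of the two numbers available; the nearest value, that of compound 1, is lower. For compound 3 only a limit is known, (the limit of > 100000 nM in this assay, at which 1 of the 3 values shown sits). Replacing the aryl group went as an at least 5.6-fold higher number from compound 1 to compound 3 (0.75 log units; beyond the scatter), so that change weakened activity beyond the scatter.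

Compound 4 `O=C1O[C@H]([C@@H](O)Cn2cc(-c3ccc(Br)cc3)nn2)C(OCc2ccccc2)=C1OCc1ccccc1` is the next step from compound 2: 4-bromophenyl in place of 3,5-difluorophenyl on an aromatic carbon. For the measured compounds named here, only one measured step touches the same position, the one from compound 1 to compound 3, and it was large and ended in a limit; the entering group there was different, so it bears only loosely on this step. Compound 4 is therefore expected to lose somewhat, a 1.5-fold higher number from compound 2 to compound 4 (0.17 log units; within the scatter), with a real chance that only a limit is reported. The estimate for compound 4 is 60000 nM, between 20000 nM and 200000 nM.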

Compound 4, half-maximal inhibitory concentration: 3910 nM
Beside the measured number, compound 4's estimate is 15-fold (1.19 log units) above it, and the stated range ends above it.
By their numbers in this assay, from the lowest: compound 4; then compound 1; then compound 2. At a limit, above all of these: compound 3.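

In this assay, 4-bromophenyl in place of 3,5-difluorophenyl brought a 10-fold lower number from compound 2 to compound 4 (1.02 log units; beyond the scatter), which shows that changing the aryl group on the triazole can also strengthen activity, and by a large margin. The number at this position can therefore move strongly in either direction, depending on the aryl group that enters. The only earlier step here went the other way and ended in a limit, for compound 3: the limit of > 100000 nM in this assay, at which 1 of the 4 values shown sits.

A single step cannot separate the effect of the bromine from that of losing the two fluorines, and it gives no reason for the gain. Also open, as far as these compounds go, is whether 4-chlorophenyl or 4-methylphenyl would behave like 4-bromophenyl, and whether 4-bromophenyl would bring a similar gain on the linker of compound 1.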